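The source may report more compounds than this note shows. Statements on the series, on what has been measured and on what is new or still open speak of the compounds shown alone.

Compound 1 `COc1cccc(NC2=CC(=O)c3c(nc4n3[C@H]3OC[C@@H](O)[C@H]3OC4)C2=O)c1`: 3830 nM
Compound 2 `O=C1C=C(Nc2ccc(C(F)(F)F)cc2)C(=O)c2c1nc1n2[C@H]2OC[C@@H](O)[C@H]2OC1`: > 4000 nM

Of the compounds shown here, two have been measured so far, and only one of them gives a plain number. In a functional assay on MCF7 cells (Homo sapiens) for inhibition, read by sulforhodamine B assay (a higher number here means a weaker inhibitor, a lower number a stronger inhibitor), compound 1 gives 3830 nM. Compound 2 gives only > 4000 nM, which is a limit of the assay rather than a number. Going by the values given here, compound 1 thus stands as the single measured value, next to the limit of > 4000 nM in this assay, at which 1 of the 2 values shown sits.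

The next compound to be measured is compound 3 `O=C1C(NC2CCCCC2)=CC(=O)c2c1nc1n2[C@H]2OC[C@@H](O)[C@H]2OC1`. It differs from compound 1 in a single place: cyclohexyl in place of 3-methoxyphenyl on an amine nitrogen. Among the compounds with values here, no measured pair of compounds differs by this same change, so there is no measured step to lean on, and the expectation rests on compound 1 alone.

In this assay the change from compound 1 to compound 3 is expected to give a step of modest size, if any beyond the scatter, most likely toward a weaker inhibitor. The step expected from compound 1 to compound 3 is a 1.4-fold higher number from compound 1 to compound 3 (0.16 log units; within the scatter). For compound 3 the estimated value is 5500 nM, within a range from 1500 nM to 20000 nM.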

Compound 3, half-maximal inhibitory concentration: > 16000 nM
Compound 3: a limit, no number; the forecaster's own chance of this, stated with the estimate: 50%; middle value at least 2.9-fold (0.46 log units) away from the limit.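

Going by these compounds alone, changing the group on this amine nitrogen gives an at least 4.1-fold higher number from compound 1 to compound 3 (0.62 log units; beyond the scatter) in this assay, the first step that can be read beyond the scatter. The earlier compounds shown here gave no such step, and this one shows that the group on this nitrogen is not interchangeable, even though compound 1 is itself only a weak inhibitor. Compound 3 gives a limit of the assay, not a number, so the step has a lower bound but no known full size: the limit of > 16000 nM in this assay, at which 1 of the 3 values shown sits.

The change does several things at once, replacing an aromatic ring with a non-aromatic one and removing the methoxy oxygen, and these compounds cannot show which of these matters. A plain phenyl group on the same nitrogen would separate the effect of the oxygen from that of the ring, while a piperidine or a longer alkyl chain would show whether other groups without an aromatic ring fare the same way as cyclohexyl.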